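Replacing 2,3-dimethylphenyl with 3-nitrophenyl in compound 3

This account rests on a few compounds, and the source may have more. Where it says the series, first, only, none or still open, it means among the compounds named here.

Three compounds share one core and differ only in the substituted phenyl group on an aromatic carbon. In a functional assay on MCF7 cells (Homo sapiens) for antiproliferative activity, read by MTT assay, with a stated time of 72 h (a lower number here means a stronger inhibitor, a higher number a weaker inhibitor), compound 1 `COc1cc(-n2cnc3ccc(-c4ccc(C)cc4F)cc32)cc(OC)c1OC` gives 56 nM as the lowest number of the three. Compound 2 `COc1ccc(-c2ccc3ncn(-c4cc(OC)c(OC)c(OC)c4)c3c2)cc1F` gives 520 nM on the same scale. Compound 3 `COc1cc(-n2cnc3ccc(-c4cccc(C)c4C)cc32)cc(OC)c1OC` gives 2150 nM and stands highest, which makes it the weakest inhibitor of the three, with compound 2 its nearest neighbour.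

Compound 4 `COc1cc(-n2cnc3ccc(-c4cccc([N+](=O)[O-])c4)cc32)cc(OC)c1OC` has 3-nitrophenyl in place of 2,3-dimethylphenyl on an aromatic carbon of compound 3 (3-nitrophenyl in place of 2,3-dimethylphenyl on an aromatic carbon). Within the data shown here, no measured compound carries this new group, so there is no direct precedent. The best guide is the set of swaps at this same place. The large step is a 38-fold higher number from compound 1 to compound 3 (1.58 log units; beyond the scatter) and the modest ones are a 9.3-fold higher number from compound 1 to compound 2 (0.97 log units; beyond the scatter) and a 4.1-fold higher number from compound 2 to compound 3 (0.62 log units; beyond the scatter) on the same scale. Going by these compounds, both other groups give lower numbers than the group in compound 3, so a modest drop is the likeliest outcome, though a wide range remains open. The expected step is a 4.3-fold lower number from compound 3 to compound 4 (0.63 log units; beyond the scatter) as a rough estimate. In this assay the estimate for compound 4 is 500 nM with an expected range from 100 nM to 2500 nM for now.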

Compound 4, half-maximal inhibitory concentration: 4560 nM
The estimate for compound 4 lay 9.1-fold (0.96 log units) below the measured number; the whole stated range lies below it.
By their numbers in this assay, from the lowest: compound 1; then compound 2; then compound 3; then compound 4.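

In this assay, the result shows that replacing the 2,3-dimethylphenyl group does not always lower the number: 3-nitrophenyl gives a 2.1-fold higher number from compound 3 to compound 4 (0.33 log units; beyond the scatter) instead of the lower numbers seen with the groups in compound 1 and compound 2. Compound 3 therefore no longer marks the weak end of this position, and the groups now span an 81-fold higher number from compound 1 to compound 4 (1.91 log units; beyond the scatter) on this carbon, with an 8.8-fold higher number from compound 2 to compound 4 (0.94 log units; beyond the scatter) as the step from the fluoro-methoxy group, so the choice of phenyl substituent here can change the number greatly while the shared core stays the same. The compounds shown include no measurement that explains these differences.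

Because 3-nitrophenyl differs from 2,3-dimethylphenyl both by gaining the nitro group and by losing two methyl groups, these compounds cannot show which of those changes matters, and a phenyl ring with one methyl group alone would help to separate them. Going by these compounds, it also remains open where a phenyl ring carrying an amine or a carboxylic acid at this place would fall, nearer to compound 1 or nearer to compound 4.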